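The compounds below may be only part of what the source reports. "The series", "measured", "known", "first", "only" and "open" are said of these compounds alone.

Compound 2 `Nc1ccc2cc(NC(=O)CCc3ccc(C(F)(F)F)cc3)ccc2n1` gives 720 nM in a functional assay on HEK293 cells for activation of melanin-concentrating hormone receptor 1 (Rattus norvegicus), read by inositol phosphate accumulation (a lower number here means that less compound is needed, a higher number that more compound is needed for the effect), the highest of the two numbers recorded so far; its nearest neighbour is compound 1 `O=C(CCc1ccc(C(F)(F)F)cc1)Nc1ccc2nc(N3CC4CC3CN4)ccc2c1`, which gives 490 nM, so that the two stand within the scatter of each other. Going by the values given here, the only measured step runs a 1.5-fold higher number from compound 1 to compound 2 (0.17 log units; within the scatter), where a group of two five-membered non-aromatic rings gives way to a single nitrogen atom on an aromatic carbon. Compound 3 `O=C(CCc1ccc(C(F)(F)F)cc1)Nc1ccc2nc(N3CC4CCC3CC4)ccc2c1` has not yet been measured. Its change from compound 2 is a group of 8 heavy atoms (7 carbon, 1 nitrogen; 2 six-membered non-aromatic rings with 1 hetero atom each) in place of one nitrogen atom, on an aromatic carbon; the entering group has no hydrogen-bond donor and one hydrogen-bond acceptor. This change mirrors the measured step, with a larger two-ring amine re-entering where the amino group sat. Because a 1.5-fold higher number from compound 1 to compound 2 (0.17 log units; within the scatter) stayed within the scatter, a similarly small step is expected here, with no movement beyond the scatter foreseen. Compound 3 is therefore expected to give 500 nM in this assay, with a range from 180 nM to 1400 nM. The expected step is a 1.4-fold lower number from compound 2 to compound 3 (0.16 log units; within the scatter).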

Compound 3, half-maximal effective concentration: 190 nM
Estimate against measurement, compound 3: 2.6-fold (0.42 log units) above; the measured number falls inside the stated range.
By their numbers in this assay, from the lowest: compound 3; then compounds 1 and 2 (each within the scatter of the next).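

In this assay this position, on an aromatic carbon next to the ring nitrogen, proves able to move the number: the group of two six-membered non-aromatic rings entering where the amino group sat gives a 3.8-fold lower number from compound 2 to compound 3 (0.58 log units; beyond the scatter) and so goes beyond the scatter, which the earlier step did not do. The two two-ring groups are not interchangeable either, since the group of 8 heavy atoms in place of the group of 7 heavy atoms, with its two five-membered non-aromatic rings, gives a 2.6-fold lower number from compound 1 to compound 3 (0.41 log units; beyond the scatter) even though compound 1 and compound 2 stand within the scatter of each other. Nothing available explains either step.

These compounds do not separate the size of the entering group from its ring sizes or from its count of nitrogen atoms, since all of these change together on going to compound 3. From the compounds shown here alone, it also remains open whether a single-ring amine such as piperidine or morpholine, or a small open-chain dimethylamino group, would stand with compound 3 or with compound 2 at this position.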